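Nitro in place of hydrogen on the shared core

The source may report more compounds than this note shows. Statements on the series, on what has been measured and on what is new or still open speak of the compounds shown alone.

Measured compounds: compound 1 `CCn1c(/C=C2/C(=O)Nc3ccccc32)nc2ccccc21`, no result; compound 2 `CC(C)n1c(/C=C2/C(=O)Nc3ccc(Cl)cc32)nc2ccccc21`, 24000 nM.

Compound 1 `CCn1c(/C=C2/C(=O)Nc3ccccc32)nc2ccccc21` has no single number in a functional assay on MCF7 cells (Homo sapiens) for cytotoxicity, read by MTT assay, with a stated time of 48 h; a lower number here means a stronger inhibitor, a higher number a weaker inhibitor; its result is "not determined" (no result reported). Going by the values given here, the only measured value comes from compound 2 `CC(C)n1c(/C=C2/C(=O)Nc3ccc(Cl)cc32)nc2ccccc21`, which in this assay gives 24000 nM. Compound 3 `CCn1c(/C=C2/C(=O)Nc3ccc([N+](=O)[O-])cc32)nc2ccccc21` is the unmeasured compound. It differs from compound 1 in one place: nitro in place of hydrogen on an aromatic carbon. Among the compounds with values here, no step between measured compounds is known here, so the size and direction of the change in this assay cannot be read from any measured pair. Within the data shown here, the one measured value, from compound 2, suggests that compounds of this core carrying a substituent at this position sit at weak potency, so no step beyond the scatter is expected for compound 3 in either direction. Compound 3 is expected to give about 15000 nM, within a range from 4000 nM to 60000 nM.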

Compound 3, half-maximal inhibitory concentration: > 50000 nM
Compound 3 ended at the assay's limit; the forecaster's own chance of this, stated with the estimate: 25%; middle value at least 3.3-fold (0.52 log units) from the limit.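

No new step can be read between compound 1 and compound 3 from these results. In this assay compound 3 gives > 50000 nM, which is a limit of the assay. The compounds shown leave open whether nitro in place of hydrogen changes potency on the shared core, and by how much.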